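This account rests on a few compounds, and the source may have more. Where it says the series, first, only, none or still open, it means among the compounds named here.

The measured compounds:
Compound 1 `C=Cc1cccc(-c2[nH]c3cc(OC)ccc3c(=O)c2C(=O)OCC)c1` — in an ADME assay on Raji cells (Homo sapiens) for cytotoxicity, read by luminescence, with a stated time of 72 h (on this read-out higher numbers stand for an effect only at larger amounts of compound and lower numbers for an effect already at smaller amounts), compound 1 gives > 21500 nM, which is a limit of the assay rather than a number.
Compound 2 `CCOC(=O)c1c(-c2cccc(OCC)c2)[nH]c2cc(OC)ccc2c1=O` — in this assay compound 2 gives > 21500 nM, again a limit and not a number.

For the measured compounds named here, compound 1 therefore stands at the limit of this assay, with no number of its own, and the single further value shown is also a limit. Going by the values given here, the only measured step, a step that the two limits leave unreadable from compound 1 to compound 2, cannot be read in size because of the limit of > 21500 nM in this assay, at which 2 of the 2 values shown sit. Compound 3 `CCOC(=O)c1c(-c2cccc(Cl)c2)[nH]c2cc(OC)ccc2c1=O` has not been measured; it differs from compound 1 by chloro in place of vinyl on an aromatic carbon. The step from compound 1 to compound 2 touches the same aromatic carbon and so bears on this change, but its size is hidden by the two limits. With no readable step in this assay, no shift beyond the scatter is expected, and the likeliest outcome for compound 3 is once more a limit. Compound 3 is thus estimated at 25000 nM, with a range from 8000 nM to 80000 nM. The step this estimate means, a step that the limit leaves unreadable from compound 1 to compound 3, is expected to stay within the scatter.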

Compound 3, half-maximal effective concentration: > 21500 nM
Compound 3: a limit, no number; the forecaster's own chance of this, stated with the estimate: 80%; the middle value lies beyond the limit too.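

With compound 3, no new step can be read in this assay, since the steps to it from compound 1 and compound 2 cannot be sized because all three compounds give only a limit: the limit of > 21500 nM in this assay, at which 3 of the 3 values shown sit.

The compounds shown leave open where each of the three truly lies beyond that limit, and whether vinyl, ethoxy and chloro on this aromatic carbon differ at all in this assay.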